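Ethyl ester to free acid: an unanchored first estimate

The compounds below may be only part of what the source reports. "The series", "measured", "known", "first", "only" and "open" are said of these compounds alone.

Compound 1 `CCOC(=O)C(=O)CC(=O)/C=C/c1cc(C(=O)c2ccccc2)cn1Cc1ccc(F)cc1` gives in an assay on isolated protein for inhibition of DNA nucleotidylexotransferase (Homo sapiens), read by scintillation counting, with a stated time of 10 min (on this read-out higher numbers stand for weaker inhibition and lower numbers for stronger inhibition), only the limit > 40 uM. Compound 2 `CCOC(=O)C(=O)CC(=O)/C=C/c1cc(C(=O)c2ccccc2)cn1Cc1ccc(C#N)cc1` in this assay likewise gives the limit > 40 uM. The step that the two limits leave unreadable from compound 1 to compound 2 therefore cannot be read, both values sitting at the limit of > 40 uM in this assay, at which 2 of the 2 values shown sit. Compound 3 `O=C(/C=C/c1cc(C(=O)c2ccccc2)cn1Cc1ccc(F)cc1)CC(=O)C(=O)O` differs from compound 1 by hydrogen in place of ethyl on an oxygen next to a carbonyl group. For the measured compounds named here, no measured step bears on this change, and compound 1 is known only as a limit, so neither direction nor size is anchored by the series. A step into the readable range is nevertheless estimated, an at least 2.0-fold lower number from compound 1 to compound 3 (0.30 log units; that floor lies within the scatter). Compound 3 is expected at 20 uM, with a range from 3 uM to 100 uM.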

Compound 3, concentration for 50% inhibition: 9.5 uM
Compound 3: middle estimate off by 2.1-fold (0.32 log units), on the high side; the measured number falls inside the stated range.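

Hydrogen in place of ethyl on an oxygen next to a carbonyl group gives the first readable step in the series: an at least 4.2-fold lower number from compound 1 to compound 3 (0.62 log units; beyond the scatter) in this assay. Compound 1 is only a limit at > 40 uM, so the true step may be larger. The earlier fluoro to cyano step cannot be read: the limit of > 40 uM in this assay, at which 2 of the 3 values shown sit.

Going by these compounds, whether the same change holds with the nitrile of compound 2 stays open. Also open, on these data alone, is whether an amide or a methyl ester in place of the carboxylic acid of compound 3 keeps its number.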